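Thioether side-chain variants on a shared core

This account rests on a few compounds, and the source may have more. Where it says the series, first, only, none or still open, it means among the compounds named here.

Values in an assay on CHO cells for displacement of a labelled ligand from adenosine receptor A1 (Homo sapiens), read by scintillation counting, with a stated time of 90 min, tested at 1 uM; on this read-out lower numbers stand for less inhibition and higher numbers for more inhibition at the one concentration tested (going by the name of the read-out):
compound 1 `N#Cc1c(N)nc(SCC(N)=O)c(C#N)c1-c1ccc(OCC2CC2)cc1` gives 31%
compound 2 `N#Cc1c(N)nc(SCC(=O)NCO)c(C#N)c1-c1ccc(OCC2CC2)cc1` gives 10%
compound 3 `N#Cc1c(N)nc(SCc2cnc[nH]2)c(C#N)c1-c1ccc(OCC2CC2)cc1` gives 1%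

Compound 2 stands second highest of the three numbers. Its nearest neighbour is compound 3, with a number 9 percentage points lower from compound 2 to compound 3 (within the scatter); compound 1 lies further off, with a number 21 percentage points lower from compound 1 to compound 2 (beyond the scatter).

The change to compound 4 `N#Cc1c(N)nc(SCn2cncn2)c(C#N)c1-c1ccc(OCC2CC2)cc1` is 1H-1,2,4-triazol-1-yl in place of (hydroxymethyl)carbamoyl on a saturated chain carbon bound to a sulfur. Among the compounds with values here, the closest precedent is a number 9 percentage points lower from compound 2 to compound 3 (within the scatter), where a five-membered aromatic ring likewise replaced the (hydroxymethyl)carbamoyl group on the saturated chain carbon bound to a sulfur; a number 30 percentage points lower from compound 1 to compound 3 (beyond the scatter) points the same way from the higher starting point. The step of a number 5 percentage points lower from compound 2 to compound 4 (within the scatter) is therefore expected to be small, downward if anything, and within the scatter. Compound 4 is estimated at 5% in this assay, with a range of -5% to 20%.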

Compound 4, a percentage reported as inhibition, at one concentration (the size of the read-out at that concentration, not a potency): 12%
Compound 4: the middle estimate sits 7 percentage points below what was measured; the range from low to high includes it.
By their numbers in this assay, from the lowest: compounds 3, 2 and 4 (each within the scatter of the next, the first and the last beyond it); then compound 1.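

In this assay, 1H-1,2,4-triazol-1-yl on a saturated chain carbon bound to a sulfur reads level with (hydroxymethyl)carbamoyl (a number 2 percentage points higher from compound 2 to compound 4 (within the scatter)). The two five-membered aromatic rings do not read alike at this place (a number 11 percentage points higher from compound 3 to compound 4 (beyond the scatter)). Carbamoyl stays apart from the triazole (a number 19 percentage points lower from compound 1 to compound 4 (beyond the scatter)), leaving compound 1 the highest of the four. Whether a carboxylic acid, a primary amine or a longer chain at this place would reach the level of compound 1 stays open, and no measurement shown accounts for these steps.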